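The source may report more compounds than this note shows. Statements on the series, on what has been measured and on what is new or still open speak of the compounds shown alone.

Measured so far:
compound 1 `NC1=NC2(CCSCC2)N(OCCCOc2cccc(Cl)c2)C(N)=N1`: 88.3%
compound 2 `NC1=NC2(CCOCC2)N(OCCCOc2cccc(Cl)c2Cl)C(N)=N1`: 81.7%

In an assay on isolated protein for inhibition of Dihydrofolate reductase (Homo sapiens), read by spectrophotometry, using NADPH, with stated times of 5 s and 6 min, tested at 5 uM (a higher number here means a stronger effect of the compound at the concentration tested, a lower number a weaker effect), compound 2 gives 81.7%. Compound 1 gives 88.3% in this assay; the gap between these two numbers lies within the scatter, so compound 2 is not set apart from compound 1. Compound 3 `NC1=NC2(CCOCC2)N(OCCCOc2cc(Cl)c(Cl)cc2Cl)C(N)=N1` has not yet been measured in this assay. The change from compound 2 is 2,4,5-trichlorophenyl in place of 2,3-dichlorophenyl on an oxygen on a saturated carbon. For the measured compounds named here, no measured pair shows a step of this kind, so the step is expected to be small, none beyond the scatter in either direction. Compound 3 is therefore expected to give about 80%, within 65% to 92%. The expected step is a number 1.7 percentage points lower from compound 2 to compound 3 (within the scatter).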

Compound 3, a percentage reported as inhibition, at one concentration (the size of the read-out at that concentration, not a potency): > 90%
Compound 3: no number, only a limit; the forecaster's own chance of this, stated with the estimate: 0%; middle value at least 10 percentage points away from the limit.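

In this assay compound 3 gives > 90%, which is a limit and not a number. For the compounds shown here, the step is a number at least 8.3 percentage points higher from compound 2 to compound 3 (that floor lies within the scatter), the first one-place comparison, and it shows that 2,4,5-trichlorophenyl in place of 2,3-dichlorophenyl on an oxygen on a saturated carbon costs no inhibition at the concentration tested. How far the step extends beyond that floor cannot be read: the limit of > 90% in this assay, at which 1 of the 3 values shown sits.

From the compounds shown here alone, whether the aromatic ring keeps this level of inhibition with an amine or a carboxylic acid in place of chlorine remains open. Also open, going by these compounds, is how a longer chain at this place would read.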